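A Smaller Group at the Aromatic Carbon of Compound 3

A few compounds are considered here, and "the series" means these few. Any claim that something is new, unique, unknown or untested is made for them only; others in the source may bear on it.

Compound 3 `CNC(=O)[C@@H](c1ccccc1)N1CCn2c(C(C)C)nc(Cl)c2[C@@H]1CCc1ccc(C(F)(F)F)cc1` gives 11 nM in a functional assay on CHO cells for antagonist activity at Orexin receptor type 2 (Homo sapiens), read by FLIPR and calcium flux (on this read-out higher numbers stand for weaker inhibition and lower numbers for stronger inhibition), the lowest of the three numbers recorded. Compound 2 `CNC(=O)[C@@H](c1ccccc1)N1CCn2c(COC)nc(Cl)c2[C@@H]1CCc1ccc(C(F)(F)F)cc1` gives 25 nM in this assay, and compound 1 `CNC(=O)[C@@H](c1ccccc1)N1CCn2c(CC3CC3)nc(Cl)c2[C@@H]1CCc1ccc(C(F)(F)F)cc1` gives 35 nM in this assay. The step of a 2.3-fold lower number from compound 2 to compound 3 (0.36 log units; beyond the scatter) and the step of a 3.2-fold lower number from compound 1 to compound 3 (0.50 log units; beyond the scatter) both lie beyond the scatter, whereas a 1.4-fold lower number from compound 1 to compound 2 (0.15 log units; within the scatter) does not.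

Compound 4 `CNC(=O)[C@@H](c1ccccc1)N1CCn2c(C)nc(Cl)c2[C@@H]1CCc1ccc(C(F)(F)F)cc1` differs from compound 3 by methyl in place of isopropyl on an aromatic carbon. The two steps that bear on this place, a 3.2-fold lower number from compound 1 to compound 3 (0.50 log units; beyond the scatter) and a 2.3-fold lower number from compound 2 to compound 3 (0.36 log units; beyond the scatter), show that exchanging cyclopropylmethyl or methoxymethyl for isopropyl lowered the number modestly. Methyl is smaller again than isopropyl, and no measured step shows what a methyl at this carbon does. A modest rise in this assay relative to compound 3 is therefore expected, though it could remain within the scatter. Compound 4 is estimated at 25 nM, with a range from 10 nM to 60 nM, which corresponds to an expected step of a 2.3-fold higher number from compound 3 to compound 4 (0.36 log units; beyond the scatter).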

Compound 4, half-maximal inhibitory concentration: 13 nM
Compound 4: middle estimate off by 1.9-fold (0.28 log units), on the high side, within the range that was stated.
By their numbers in this assay, from the lowest: compounds 3, 4, 2 and 1 (each within the scatter of the next, the first and the last beyond it).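

Methyl in place of isopropyl on this aromatic carbon gives a 1.2-fold higher number from compound 3 to compound 4 (0.07 log units; within the scatter), so in this assay the low number of compound 3 does not depend on isopropyl as such, and the earlier compounds could not show this. Against the longer groups the picture is split: a 2.7-fold lower number from compound 1 to compound 4 (0.43 log units; beyond the scatter) separates methyl from cyclopropylmethyl, whereas a 1.9-fold lower number from compound 2 to compound 4 (0.28 log units; within the scatter) does not separate it from methoxymethyl, although compound 3 stood apart from compound 2 by more than the scatter. Nothing given here accounts for these results.

Going by these compounds, it remains open how an amine, a carboxylic acid or a lone hydrogen on this aromatic carbon would read in this assay. On these data alone, it is equally open whether methyl and isopropyl would still match if the chloro group two ring bonds away were replaced by a nitrile.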